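This account rests on a few compounds, and the source may have more. Where it says the series, first, only, none or still open, it means among the compounds named here.

Compound 1 `O=C(NO)c1ccc(/C=C/c2ccnc(-c3ccccc3O)c2)cc1` gives 47 nM in an assay on isolated protein for inhibition of protein deacetylase HDAC6 (Homo sapiens), read by fluorescence, with a stated time of 15 min; a higher number here means a weaker inhibitor, a lower number a stronger inhibitor. Compound 2 `O=C(NO)c1ccc(/C=C/c2ccnc(-c3cccnc3)c2)cc1` gives 14 nM.

Compound 1 stands with the highest of the two numbers; its nearest neighbour is compound 2, reached by a 3.4-fold lower number from compound 1 to compound 2 (0.53 log units; beyond the scatter). Compound 3 `Cc1ccc(-c2cc(/C=C/c3ccc(C(=O)NO)cc3)ccn2)cc1` is not yet measured. Compared with compound 1 it carries 4-methylphenyl in place of 2-hydroxyphenyl on an aromatic carbon. Going by the values given here, the only measured step that bears on this position is the one from compound 1 to compound 2, a modest step at the same aromatic carbon toward a lower number. Since the entering group differs from both, compound 3 is expected to land near compound 1, with a 1.6-fold lower number from compound 1 to compound 3 (0.19 log units; within the scatter) toward a somewhat lower number. The value of compound 3 is estimated at 30 nM, within 10 nM to 90 nM.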

Compound 3, half-maximal inhibitory concentration: 150 nM
Beside the measured number, compound 3's estimate is 5.0-fold (0.70 log units) below it; the whole stated range lies below it.
By their numbers in this assay, from the lowest: compound 2; then compound 1; then compound 3.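

Placing 4-methylphenyl in place of 2-hydroxyphenyl gives a 3.2-fold higher number from compound 1 to compound 3 (0.50 log units; beyond the scatter), so changes at this aromatic carbon can also raise the number, whereas the earlier step had gone only toward a lower one. Set against pyridin-3-yl, the same group gives an 11-fold higher number from compound 2 to compound 3 (1.03 log units; beyond the scatter), the widest gap among the three compounds in this assay. Nothing available accounts for these differences.

As far as these compounds go, what remains open is how an unsubstituted phenyl would stand against these three compounds, which would separate the methyl from the ring it sits on. From the compounds shown here alone, a 4-hydroxyphenyl or a morpholine at this carbon is equally open.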